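Series notes: ester to ketone at the carbonyl

This account rests on a few compounds, and the source may have more. Where it says the series, first, only, none or still open, it means among the compounds named here.

Three members of this series have a number in a physicochemical assay for lipophilicity; a lower number here means a more polar compound, a higher number a more lipophilic compound. Compound 1 `C=CCOC(=O)/C=C(C)/C=C/CC(C)CCCC(C)C` gives 6.73 in this assay. Compound 2 `C/C=C/COC(=O)/C=C(C)/C=C/CC(C)CCCC(C)(C)OC` gives 6.07 in this assay. Compound 3 `CCOC(=O)/C=C(C)/C=C/CC(C)CCCC(C)(C)OCC` gives 6.08 in this assay. Among the three, compound 2 stands lowest; its nearest neighbour is compound 3, whose number lies within the scatter, so no order between these two can be read, while compound 1 lies furthest away, beyond the scatter.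

Compound 4 `CCC(C)C(=O)/C=C(C)/C=C/CC(C)CCCC(C)(C)OC` has not yet been measured in this assay. It differs from compound 2 in a single place: sec-butyl in place of (but-2-en-1-yl)oxy on a carbonyl carbon. Among the measured compounds shown here, no measured pair shows the same change, so the step has to be judged from the structural difference alone.

The expectation is a small step, if any, from compound 2 to compound 4, of the order of a number 0.13 log units higher from compound 2 to compound 4 (within the scatter), which would fall within the scatter of this assay; the direction is not secure, with a slight rise judged a little more likely than a fall. For compound 4 the value in this assay is estimated at 6.2, with a range from 5.7 to 6.7.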

Compound 4, partition coefficient: 6.02
The estimate for compound 4 lay 0.18 log units above the measured number, and the stated range covers the measured number.
By their numbers in this assay, from the lowest: compounds 4, 2 and 3 (each within the scatter of the next); then compound 1.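

Among the compounds shown here, this is the first step that can be read at this position. In this assay, sec-butyl in place of (but-2-en-1-yl)oxy on a carbonyl carbon gives a number 0.05 log units lower from compound 2 to compound 4 (within the scatter), so compound 2 and compound 4 cannot be put in order, and turning this ester into a ketone shows no readable shift in this pair. The step stays inside the scatter although the leaving group carries 5 heavy atoms, 1 double bond outside aromatic rings and 1 hydrogen-bond acceptor, while the entering group carries 4 heavy atoms, no such double bond and 0 hydrogen-bond acceptors; nothing on hand explains this outcome.

The compounds shown leave open whether other groups on the same carbonyl carbon, such as an amine, a hydroxyl giving the carboxylic acid, or a longer chain, would also stay within the scatter of compound 2. From the compounds shown here alone, the reading also rests on a single pair, so it remains open whether the same change would give a similar step from the other esters.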